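From compound 3 to its mirror image

The source may report more compounds than this note shows. Statements on the series, on what has been measured and on what is new or still open speak of the compounds shown alone.

Values in an ADME assay on microsomes from liver (Homo sapiens) for metabolic stability (on this read-out higher numbers stand for fast clearance and lower numbers for slow clearance), for the three measured compounds:
- compound 1 `O=C(Nc1ccc(Cl)cc1)C(=O)N1CCC(c2ccnc3ccc(F)cc23)CC1` gives 9 mL.min-1.g-1
- compound 2 `CC1(C)CN(C(=O)C(=O)Nc2ccc(Cl)cc2)CCC1c1ccnc2ccc(F)cc12` gives 28.8 mL.min-1.g-1
- compound 3 `O=C(Nc1ccc(Cl)cc1)C(=O)N1CC[C@H](c2ccnc3ccc(F)cc23)[C@@H](O)C1` gives 4 mL.min-1.g-1

Compound 3 stands lowest of the three in this assay with compound 1 nearest and compound 2 furthest. The next compound, compound 4 `O=C(Nc1ccc(Cl)cc1)C(=O)N1CC[C@@H](c2ccnc3ccc(F)cc23)[C@H](O)C1`, is its mirror image (the two compounds have the same atoms and bonds and differ only in configuration as drawn: 2 of 2 stereo elements differ (all stereocentres are inverted: mirror images); a stereocentre at a saturated ring carbon is drawn R in compound 3 and S in compound 4; a stereocentre at a saturated ring carbon is drawn R in compound 3 and S in compound 4). Going by the values given here, the only measured step that bears on this is hydroxy in place of hydrogen on a saturated ring carbon (a 2.3-fold lower number from compound 1 to compound 3 (0.35 log units; beyond the scatter)), and that step does not compare configurations. Among the compounds with values here, no mirror-image pair has been measured, so no direction can be argued. The expected change is therefore none beyond the scatter (a 1.3-fold higher number from compound 3 to compound 4 (0.10 log units; within the scatter)). The estimated value for compound 4 is 5 mL.min-1.g-1 (2.5 mL.min-1.g-1 to 11 mL.min-1.g-1).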

Compound 4, intrinsic clearance in microsomes: 5 mL.min-1.g-1
Compound 4: the middle estimate sits on the measured number at the digits printed, within the range that was stated.
By their numbers in this assay, from the lowest: compounds 3, 4 and 1 (each within the scatter of the next, the first and the last beyond it); then compound 2.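

In this assay, inverting both stereocentres gives a 1.3-fold higher number from compound 3 to compound 4 (0.10 log units; within the scatter) and so the read-out does not separate this mirror-image pair. This comparison isolates configuration alone: the fact that compounds 3 and 4 differ only in the configuration as drawn. Set against the parent without the hydroxy, the same replacement gives a 1.8-fold lower number from compound 1 to compound 4 (0.26 log units; within the scatter) in this mirror-image form, whereas the other form gave a 2.3-fold lower number from compound 1 to compound 3 (0.35 log units; beyond the scatter) and so only that step lies beyond the scatter.

The compounds shown leave open how a methoxy group or an amine on that ring carbon would read. They also leave open whether the two hydroxy compounds with the other relative configuration would match this pair.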